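Difluoromethyl in place of ethyl on the core of compound 1

The compounds below may be only part of what the source reports. "The series", "measured", "known", "first", "only" and "open" are said of these compounds alone.

Measured so far in an assay for binding affinity to Corticotropin releasing factor receptor (Rattus norvegicus); on this read-out higher numbers stand for weaker inhibition and lower numbers for stronger inhibition:
compound 1 `CCCC(C)n1c(CC)nc2c(-c3ccc(Cl)cc3Cl)ccnc21` gives 0.5 nM
compound 2 `CCc1nc2c(-c3ccc(Cl)cc3Cl)ccnc2n1C(CC)CC` gives 1 nM
compound 3 `CCCC(C)n1c(CC)nc2c(-c3ccc(C(C)O)cc3Cl)ccnc21` gives 5.1 nM

Compound 1 has the lowest of the three numbers. Compound 2 sits within the scatter of it (a 2.0-fold higher number from compound 1 to compound 2 (0.30 log units; within the scatter)), while compound 3 lies well beyond it (a 10-fold higher number from compound 1 to compound 3 (1.01 log units; beyond the scatter)). Compound 4 `CCCC(C)n1c(C(F)F)nc2c(-c3ccc(Cl)cc3Cl)ccnc21` differs from compound 1 in one place: difluoromethyl in place of ethyl on an aromatic carbon. Neither measured step touches this site: the step to compound 2 changes the group on the aromatic nitrogen, and the step to compound 3 exchanges chloro for 1-hydroxyethyl on an aromatic carbon. The change is thus untested here. Only a small step, if any, is expected, estimated as a 3.0-fold higher number from compound 1 to compound 4 (0.48 log units; beyond the scatter). Compound 4 is expected at 1.5 nM, between 0.4 nM and 6 nM.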

Compound 4, inhibition constant: 15.8 nM
Estimate against measurement, compound 4: 11-fold (1.02 log units) below; the whole stated range lies below it.
By their numbers in this assay, from the lowest: compounds 1 and 2 (each within the scatter of the next); then compound 3; then compound 4.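

The site between two ring nitrogen atoms proves sensitive: in this assay, swapping ethyl for difluoromethyl gives a 32-fold higher number from compound 1 to compound 4 (1.50 log units; beyond the scatter) and so weakens inhibition markedly. A change at this carbon alone is therefore enough to move the result well beyond the scatter, even though the group gains only one heavy atom. No available measurement accounts for the size of this step. The compounds shown leave open how a methyl group or a propyl chain would fare at this carbon. They also leave open whether difluoromethyl would cost as much alongside the pentan-3-yl group of compound 2.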